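The compounds below may be only part of what the source reports. "The series", "measured", "known", "first", "only" and "open" are said of these compounds alone.

Measured in a functional assay on MDA-MB-231 cells (Homo sapiens) for antiproliferative activity, read by MTT assay, with a stated time of 72 h; on this read-out lower numbers stand for stronger inhibition and higher numbers for weaker inhibition:
- Compound 1 `CC1=CC[C@H]2[C@@H]1CC=C(C)[C@@H](CCC1=C(C)CC[C@@H]3OC(C)(C)[C@@H](O)CC[C@@]13C)C2(C)C`: > 50000 nM
- Compound 2 `CC1=CC[C@H]2[C@H](CC[C@]2(C)O)C(C)(C)[C@@H]1CC[C@H]1[C@]2(C)CC[C@H](OC(=O)CCC(=O)O)C(C)(C)O[C@H]2CC[C@@]1(C)O`: 27900 nM

Compound 1 shows > 50000 nM, which is a limit of the assay and not a number. Going by the values given here, compound 2 gives 27900 nM, the only true number so far, and this makes it the single reference point for what follows.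

Compound 3 `CC1=CC[C@H]2[C@H](CC[C@]2(C)O)C(C)(C)[C@@H]1CC[C@H]1[C@]2(C)CC[C@H](OC(=O)c3ccncc3)C(C)(C)O[C@H]2CC[C@@]1(C)O` has not yet been measured. It keeps the core of compound 2 and differs in one place: pyridin-4-yl in place of 2-carboxyethyl on a carbonyl carbon. Here, pyridin-4-yl stands in place of 2-carboxyethyl on a carbonyl carbon.

Among the compounds with values here, no measured pair of compounds differs in just one place, so there is no step to gauge this change against, and any expectation is rough. The expected change is small and toward stronger inhibition, a 1.6-fold lower number from compound 2 to compound 3 (0.19 log units; within the scatter). For compound 3 the estimated value is 18000 nM, with an expected range of 6000 nM to 50000 nM.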

Compound 3, half-maximal inhibitory concentration: 18000 nM
Compound 3: the middle estimate sits on the measured number at the digits printed; the range from low to high includes it.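

In this assay, putting pyridin-4-yl in place of 2-carboxyethyl on a carbonyl carbon gives a 1.6-fold lower number from compound 2 to compound 3 (0.19 log units; within the scatter), so this change does not separate the two compounds. Going by these compounds alone, this is the first sign that this position can lose an open chain carrying a hydrogen-bond donor and take a six-membered aromatic ring without the number moving beyond the usual scatter of the assay. Nothing measured here explains this step.

The compounds shown leave open whether the ring nitrogen matters, which a plain phenyl ring or a pyridin-3-yl group in the same place could test. They also leave open whether an amine or a longer chain ending in a carboxylic acid would shift the number beyond the scatter.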